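The compounds below may be only part of what the source reports. "The series", "measured", "known", "first", "only" and "open" are said of these compounds alone.

Measured compounds:
compound 1, `COc1ccc2c(c1)[C@@H](O)CN(C)C2`: > 100000 nM
compound 2, `CN1Cc2ccc(OCc3ccc([N+](=O)[O-])cc3)cc2[C@@H](O)C1`: > 50000 nM

In an ADME assay on Vero cells (Chlorocebus sabaeus) for cytotoxicity, read by sulforhodamine B assay, with a stated time of 72 h (on this read-out lower numbers stand for stronger inhibition and higher numbers for weaker inhibition), compound 1 gives > 100000 nM. This is a limit of the assay and not a number, so compound 1 stands only at the limit of > 100000 nM in this assay, at which 1 of the 2 values shown sits. Compound 2 gives > 50000 nM in this assay. That value too is a limit of the assay, sitting at the limit of > 50000 nM in this assay, at which 1 of the 2 values shown sits. Within the data shown here, with both values given only as limits, no step between measured compounds can be worked out, and the two values show no more than that neither compound reached a measurable half-maximal inhibitory concentration within the tested range.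

Compound 3, `Cc1ccccc1COc1ccc2c(c1)[C@@H](O)CN(C)C2`, is not yet measured. It differs from compound 1 by 2-methylphenyl in place of hydrogen on a saturated chain carbon bound to an oxygen on an aromatic ring. Among the measured compounds shown here, no step of this kind has been measured, and both measured compounds sit at limits, so no direction can be read from the numbers. The expected step is none beyond the scatter, an at least 1.2-fold lower number from compound 1 to compound 3 (0.09 log units; that floor lies within the scatter). Compound 3 is therefore estimated at 80000 nM, with a range from 30000 nM to 200000 nM, and the assay is expected most likely to return again only a limit rather than a number.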

Compound 3, half-maximal inhibitory concentration: > 100000 nM
Compound 3 was reported as a limit; the forecaster's own chance of this, stated with the estimate: 70%; at least 1.2-fold (0.09 log units) between middle value and limit.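

In this assay compound 3 gives > 100000 nM, which is a limit of the assay. Compound 1 gives > 100000 nM, also a limit, so no new step can be read between compound 1 and compound 3. The compounds shown leave open whether any member of this series reaches a measurable half-maximal inhibitory concentration in this assay.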